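Moving one fluorine on the indole of compound 1

The source may report more compounds than this note shows. Statements on the series, on what has been measured and on what is new or still open speak of the compounds shown alone.

Measured in a functional assay on HCT-116 cells (Homo sapiens) for antiproliferative activity, with a stated time of 72 h; on this read-out lower numbers stand for stronger inhibition and higher numbers for weaker inhibition:
- compound 1 `O=C(COc1ccc(CNC2CC=C(c3c[nH]c4cccc(F)c34)CC2)c(F)c1)NO`: 173 nM
- compound 2 `O=C(COc1ccc(CN2CC=C(c3c[nH]c4ccc(F)cc34)CC2)cc1)NO`: 949 nM
- compound 3 `Cc1[nH]c2ccccc2c1C1=CCC(NC(=O)c2ccc(OCC(=O)NO)cc2)CC1`: > 5000 nM

Compound 1, at 173 nM, has the lower of the two exact numbers. Compound 2 is the nearest, and its 949 nM is higher by more than the usual scatter. Compound 3 has no exact number, and its > 5000 nM is a limit of the assay.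

Compound 4 `O=C(COc1ccc(CNC2CC=C(c3c[nH]c4ccc(F)cc34)CC2)c(F)c1)NO` has not yet been measured. It has the same atoms as compound 1, joined differently: 5-fluoro-1H-indol-3-yl in place of 4-fluoro-1H-indol-3-yl on a double-bonded ring carbon. In words, 5-fluoro-1H-indol-3-yl stands in place of 4-fluoro-1H-indol-3-yl on a double-bonded ring carbon. Within the data shown here, no pair of measured compounds shows a change of this kind, so the size of the step is uncertain. The expectation therefore starts from compound 1 at 173 nM: in this assay, a step within the scatter is expected, with no firm direction. The estimate is a 1.3-fold higher number from compound 1 to compound 4 (0.10 log units; within the scatter). For compound 4 the estimated value is 220 nM, with an expected range from 80 nM to 600 nM.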

Compound 4, half-maximal inhibitory concentration: 261 nM
Compound 4: middle estimate off by 1.2-fold (0.07 log units), on the low side; the measured number falls inside the stated range.
By their numbers in this assay, from the lowest: compounds 1 and 4 (each within the scatter of the next); then compound 2. At a limit, above all of these: compound 3.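

In this assay, among these compounds, placing 5-fluoro-1H-indol-3-yl where compound 1 carries 4-fluoro-1H-indol-3-yl gives a 1.5-fold higher number from compound 1 to compound 4 (0.18 log units; within the scatter) and so gives the first direct reading of this change, since no earlier pair of compounds differed in only one place. For these two placements of the fluorine, the assay does not separate the compounds, and the rest of the structure is held constant in the comparison. Nothing measured here explains why the two placements read alike.

From the compounds shown here alone, it remains open whether the fluorine itself matters, which a plain 1H-indol-3-yl group would help to show. A chlorine, a methoxy group or a nitrile in its place could also show whether this part of the molecule tolerates larger changes than a shift of one fluorine.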